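The source may report more compounds than this note shows. Statements on the series, on what has been measured and on what is new or still open speak of the compounds shown alone.

Compound 1 `O=C(Nc1cccc(-n2cc(-c3ccncc3)c(-c3ccc(Cl)c(O)c3)n2)c1)Nc1cccc(C(F)(F)F)c1` is one of three analogues of a shared core tested in a functional assay on MCF7 cells (Homo sapiens) for inhibition, read by sulforhodamine B assay, with a stated time of 48 h; a higher number here means a weaker inhibitor of growth, a lower number a stronger inhibitor of growth; compound 1 gives 1340 nM. Compound 2 `O=C(Nc1cccc(-n2cc(-c3ccncc3)c(-c3ccc(Cl)c(O)c3)n2)c1)Nc1ccc(Cl)c(Cl)c1` gives 1060 nM and compound 3 `COc1cc(-c2nn(-c3cccc(NC(=O)Nc4cccc(C(F)(F)F)c4)c3)cc2-c2ccncc2)ccc1Cl` gives 751 nM, so the three numbers sit together, each within the scatter of compound 1. The step of a 1.3-fold lower number from compound 1 to compound 2 (0.10 log units; within the scatter) replaces the aryl group on the amide-type nitrogen; the step of a 1.8-fold lower number from compound 1 to compound 3 (0.25 log units; within the scatter) alters an oxygen elsewhere on the core. Compound 4 `O=C(Nc1cccc(-n2cc(-c3ccncc3)c(-c3ccc(Cl)c(O)c3)n2)c1)Nc1cc(C(F)(F)F)cc(C(F)(F)F)c1` carries trifluoromethyl in place of hydrogen on an aromatic carbon. Only a 1.3-fold lower number from compound 1 to compound 2 (0.10 log units; within the scatter) bears on the same aryl group, and it remained within the scatter, so no step beyond the scatter is expected in this assay. Compound 4 is estimated at 1200 nM, with a range from 500 nM to 3000 nM. That expectation amounts to a step of a 1.1-fold lower number from compound 1 to compound 4 (0.05 log units; within the scatter).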

Compound 4, concentration for 50% growth inhibition: 540 nM
Compound 4: the middle estimate sits 2.2-fold (0.35 log units) above what was measured, and the stated range covers the measured number.
By their numbers in this assay, from the lowest: compounds 4, 3, 2 and 1 (each within the scatter of the next, the first and the last beyond it).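

In this assay, trifluoromethyl on this aromatic carbon, meta to the existing trifluoromethyl group, gives a 2.5-fold lower number from compound 1 to compound 4 (0.39 log units; beyond the scatter) and is the only step shown that lies beyond the scatter, though it is modest. The aryl group on the amide-type nitrogen therefore does respond to substitution, which the change to 3,4-dichlorophenyl, at a 1.3-fold lower number from compound 1 to compound 2 (0.10 log units; within the scatter), could not show. Nothing available accounts for this step.

As far as these compounds go, whether a nitrile, an amine or a carboxylic acid on this carbon would give a similar step remains open. Also open, from the compounds shown here alone, is whether the second trifluoromethyl group would have the same effect on the methoxy-bearing core of compound 3.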